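The compounds below may be only part of what the source reports. "The series", "measured", "known", "first", "only" and "open" are said of these compounds alone.

Measured so far in an assay on SH-EP1 cells for agonist activity at Neuronal acetylcholine receptor; alpha4/beta2 (Homo sapiens), read by FLIPR and calcium flux; a lower number here means a smaller maximal response, a higher number a larger maximal response:
compound 1 `O=C([C@H]1C[C@H]1F)N1CC2CC(C1)N2`: 110%
compound 2 `O=C([C@@H]1C[C@H]1F)N1CC2CC(C1)N2`: 110%

Compound 2 stands level with compound 1 in this assay, the step of no change at the digits printed from compound 1 to compound 2 (within the scatter) lying within the scatter; the only difference between them is the fact that one of compounds 1 and 2 is drawn with a defined configuration and the other without, at the place where they differ, a stereocentre at a saturated ring carbon. Compound 3 `C[C@@H]1C[C@H]1C(=O)N1CC2CC(C1)N2` is not yet measured. It differs from compound 2 by methyl in place of fluoro on a saturated ring carbon. Within the data shown here, no measured step bears on this change: the single step recorded, no change at the digits printed from compound 1 to compound 2 (within the scatter), concerns configuration only and says nothing about exchanging a fluoro for a methyl on the three-membered ring. Among the measured compounds shown here, both measured compounds reach a full response, so the default expectation for compound 3 is a response in the same region, with a wider range because no step with a substituent change is available; the expected step is a number 10 percentage points lower from compound 2 to compound 3 (within the scatter). Compound 3 is therefore estimated at 100%, between 70% and 120%.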

Compound 3, largest response reached (Emax), in percent of the reference or control that the assay uses: 110%
For compound 3 the middle estimate is 10 percentage points below the measured one, and the stated range covers the measured number.
By their numbers in this assay, from the lowest: compounds 1, 2 and 3 (each within the scatter of the next).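

In this assay, methyl in place of fluoro on the saturated ring carbon gives no change at the digits printed from compound 2 to compound 3 (within the scatter), the first substituent change read at this position. The exchange of 2-fluorocyclopropyl for 2-methylcyclopropyl on the carbonyl carbon reads the same, no change at the digits printed from compound 1 to compound 3 (within the scatter), so among compounds 1, 2 and 3 the maximal response stays level with either group at this place. Nothing at hand bears on the reason for this outcome.

As far as these compounds go, what an amine, a carboxylic acid or a longer chain such as butyl would give on the same ring carbon remains open. From the compounds shown here alone, it also remains open whether any group at this place can move the maximal response beyond the scatter.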